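A few compounds are considered here, and "the series" means these few. Any claim that something is new, unique, unknown or untested is made for them only; others in the source may bear on it.

Compound 3, `CC1CCCCN1C(=S)SCc1ccc(C(=O)Nc2ccccc2N)cc1`, stands highest of the three measured compounds in a functional assay on A-375 cells (Homo sapiens) for antiproliferative activity, read by CCK-8 assay, with a stated time of 72 h, tested at 2 uM; a higher number here means a stronger effect of the compound at the concentration tested, a lower number a weaker effect. In this assay compound 3 gives 42.5%. Compound 1, `Nc1ccccc1NC(=O)c1ccc(CSC(=S)N2CCN(c3ccc(Cl)cc3)CC2)cc1`, gives 32.2%, and compound 2, `Nc1ccccc1NC(=O)c1ccc(CSC(=S)N2CCN(C3CCCCC3)CC2)cc1`, gives 31.7%; both lie beyond the scatter below compound 3. Among the compounds with values here, the one measured step, a number 0.5 percentage points lower from compound 1 to compound 2 (within the scatter), changed the group on an amine nitrogen in a ring and stayed within the scatter.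

Compound 4, `CCN(Cc1ccncc1)C(=S)SCc1ccc(C(=O)Nc2ccccc2N)cc1`, differs from compound 3 at the thiocarbonyl carbon: ethyl((pyridin-4-yl)methyl)amino in place of 2-methylpiperidin-1-yl on a thiocarbonyl carbon. Within the data shown here, no measured step replaces the ring on that carbon with an open chain, so the step from compound 1 to compound 2 bears on it only loosely, as a sign that changes in this part of the molecule have so far moved the numbers little. A modest downward step is therefore expected, with a number 7.5 percentage points lower from compound 3 to compound 4 (within the scatter). For compound 4 the estimate is 35%, expected to fall between 22% and 48%.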

Compound 4, a percentage reported as inhibition, at one concentration (the size of the read-out at that concentration, not a potency): 67.2%
For compound 4 the middle estimate is 32.2 percentage points below the measured one, outside the stated range (above it).
By their numbers in this assay, from the lowest: compounds 2 and 1 (each within the scatter of the next); then compound 3; then compound 4.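

Within the data shown here, on the thiocarbonyl carbon, ethyl((pyridin-4-yl)methyl)amino in place of 2-methylpiperidin-1-yl gives a number 24.7 percentage points higher from compound 3 to compound 4 (beyond the scatter) in this assay, so this position can shift the read-out well beyond the scatter, unlike the one earlier change, at an amine nitrogen in a ring, which gave a number 0.5 percentage points lower from compound 1 to compound 2 (within the scatter) and stayed within it. The entering group differs in several ways at once, opening the non-aromatic ring into an ethyl group and adding a (pyridin-4-yl)methyl group with its aromatic ring, so this single step cannot show which part goes with the higher number. Nothing measured here explains the rise.

Going by these compounds, it remains open whether the nitrogen of the pyridin-4-yl ring matters, which a benzyl group in place of (pyridin-4-yl)methyl could test. A propyl group in place of the ethyl would show whether the length of that chain also matters.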